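Adding One Carbon to the Ester Chain

This account rests on a few compounds, and the source may have more. Where it says the series, first, only, none or still open, it means among the compounds named here.

Compound 2 `CCCCCCCCCCCCCCCCCCOC(=O)CCC(=O)N1CCN(CCCOc2cc3c(Nc4ccc(F)c(Cl)c4)ncnc3cc2OC)CC1` gives, in a functional assay on A549 cells (Homo sapiens) for cytotoxicity, read by MTT assay, with a stated time of 24 h, tested at 60 uM (on this read-out higher numbers stand for a weaker effect at the one concentration tested and lower numbers for a stronger effect), a value of 87.2%. Compound 1 `CCCCCCCCCCCCCCCOC(=O)CCC(=O)N1CCN(CCCOc2cc3c(Nc4ccc(F)c(Cl)c4)ncnc3cc2OC)CC1` gives 81.6%, so compound 2 stands at the upper end of the two numbers shown, though the step of a number 5.6 percentage points higher from compound 1 to compound 2 (within the scatter) lies within the scatter. Compound 3 `CCCCCCCCCCCCCCCCCCCOC(=O)CCC(=O)N1CCN(CCCOc2cc3c(Nc4ccc(F)c(Cl)c4)ncnc3cc2OC)CC1` differs from compound 2 by methyl in place of hydrogen on a saturated chain carbon, ten or more bonds along the chain from an oxygen next to a carbonyl group. Among the compounds with values here, the only measured step that bears on this change is that one, propyl in place of hydrogen at the same place, and it stayed within the scatter, so a step of a number 0.8 percentage points higher from compound 2 to compound 3 (within the scatter) is expected, none beyond the scatter. Compound 3 is therefore estimated at 88%, with a range from 78% to 96%.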

Compound 3, a percentage reported as activity, at one concentration (the size of the read-out at that concentration, not a potency): 89.3%
Compound 3: the middle estimate sits 1.3 percentage points below what was measured; low and high end bracket the measured number.
By their numbers in this assay, from the lowest: compounds 1, 2 and 3 (each within the scatter of the next).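

Methyl in place of hydrogen at this far point of the ester chain gives a number 2.1 percentage points higher from compound 2 to compound 3 (within the scatter), and butyl in place of hydrogen gives a number 7.7 percentage points higher from compound 1 to compound 3 (within the scatter). Even the largest change in chain length among these three compounds therefore stays within the scatter in this assay, so the compounds cannot be ranked by chain length. Nothing available explains these numbers. Still open, from the compounds shown here alone, is whether a much shorter chain, or an amine or a carboxylic acid in place of this chain, would move the number beyond the scatter.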